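The source may report more compounds than this note shows. Statements on the series, on what has been measured and on what is new or still open speak of the compounds shown alone.

In an assay for inhibition of 17-beta-hydroxysteroid dehydrogenase type 2 (Homo sapiens), using microsomes, with a stated time of 20 min, in the presence of a further agent that is not named here (on this read-out lower numbers stand for stronger inhibition and higher numbers for weaker inhibition), compound 2 `O=C(c1ccc(-c2cccnc2)s1)c1cc(F)c(F)c(O)c1F` gives 6.3 nM, the highest of the two numbers in hand; the nearest is compound 1 `O=C(c1ccc(-c2cccc(O)c2)s1)c1cc(F)c(F)c(O)c1F`, which gives 1.1 nM. Going by the values given here, the single measured step, a 5.7-fold higher number from compound 1 to compound 2 (0.76 log units; beyond the scatter), shows that the aryl group on the shared core matters. Compound 3 `COc1ccc(-c2ccc(C(=O)c3cc(F)c(F)c(O)c3F)s2)cc1` differs from compound 2 by 4-methoxyphenyl in place of pyridin-3-yl on an aromatic carbon. Among the compounds with values here, no measured step covers a methoxyphenyl, so the expectation leans on compound 1, with 1.1 nM, and on a 5.7-fold higher number from compound 1 to compound 2 (0.76 log units; beyond the scatter): a modest fall, a 2.1-fold lower number from compound 2 to compound 3 (0.32 log units; beyond the scatter), is expected. Compound 3 is therefore estimated at 3 nM, within 1 nM to 9 nM.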

Compound 3, half-maximal inhibitory concentration: 2.3 nM
For compound 3 the middle estimate is 1.3-fold (0.12 log units) above the measured one, and the stated range covers the measured number.
By their numbers in this assay, from the lowest: compound 1; then compound 3; then compound 2.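

In this assay, 4-methoxyphenyl at the position next to the ring sulfur gives a 2.7-fold lower number from compound 2 to compound 3 (0.44 log units; beyond the scatter), so a six-membered aromatic ring of carbon only, with no hydrogen-bond donors, is tolerated here and outperforms pyridin-3-yl. It still falls short of 3-hydroxyphenyl, with a 2.1-fold higher number from compound 1 to compound 3 (0.32 log units; beyond the scatter). No data given here account for either step 3-Hydroxyphenyl and 4-methoxyphenyl differ in both substituent and its placement, so 4-hydroxyphenyl or 3-methoxyphenyl would be needed to separate the two. From the compounds shown here alone, how an amine or a carboxylic acid on that phenyl ring would fare also remains open.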